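The source may report more compounds than this note shows. Statements on the series, on what has been measured and on what is new or still open speak of the compounds shown alone.

Measured so far:
compound 1, `O=c1cc(NC2CCCCC2)cc(/C=C/c2ccccc2)o1`: 1.24 uM
compound 2, `O=c1cc(NC2CC2)cc(-c2ccccc2)o1`: > 30 uM
compound 3, `COc1ccc(Nc2cc(C3CCCCC3)oc(=O)c2)cc1`: 4.39 uM

In a functional assay on KBVIN cells (Homo sapiens) for cytotoxicity, read by MTT assay, with a stated time of 72 h (on this read-out higher numbers stand for an effect only at larger amounts of compound and lower numbers for an effect already at smaller amounts), compound 1 gives 1.24 uM and compound 3 gives 4.39 uM. For compound 2 the result is only a limit, (the limit of > 30 uM in this assay, at which 1 of the 3 values shown sits), and not a number. Of the two numbers, compound 3 holds the higher one, and its gap to compound 1 lies beyond the scatter. Compound 4, `COc1ccc(Nc2cc(/C=C/c3ccccc3)oc(=O)c2)cc1`, is not yet measured; it differs from compound 3 in one place: 2-phenylethenyl in place of cyclohexyl on an aromatic carbon. Compound 1 carries the same 2-phenylethenyl group and gives 1.24 uM. On that basis a moderate step toward a lower number is expected, a 2.2-fold lower number from compound 3 to compound 4 (0.34 log units; beyond the scatter) in this assay. The estimated value for compound 4 in this assay is 2 uM, with a likely range from 0.6 uM to 6 uM.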

Compound 4, concentration for half-maximal effect: 0.1 uM
Estimate against measurement, compound 4: 20-fold (1.30 log units) above; the measured number lies below the stated range.
By their numbers in this assay, from the lowest: compound 4; then compound 1; then compound 3. At a limit, above all of these: compound 2.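

In this assay, 2-phenylethenyl in place of cyclohexyl on the aromatic carbon next to the ring oxygen gives a 44-fold lower number from compound 3 to compound 4 (1.64 log units; beyond the scatter), so this position responds strongly to the change when the nitrogen carries 4-methoxyphenyl. With 2-phenylethenyl held in place, 4-methoxyphenyl in place of cyclohexyl on the nitrogen gives a 12-fold lower number from compound 1 to compound 4 (1.09 log units; beyond the scatter), so the group on the nitrogen matters too. Nothing measured here tells why either step is so large. The compounds shown leave open whether 2-phenylethyl, the same chain without its double bond, would keep the low number at this position.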